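The source may hold more compounds than are shown below. What is called first, only, known or untested is meant among the compounds shown, and "the series" means these compounds.

In a functional assay on Bel-7402 cells (Homo sapiens) for inhibition, read by MTT assay, with a stated time of 24 h, tested at 1 ug/mL (on this read-out lower numbers stand for less inhibition of growth and higher numbers for more inhibition of growth at the one concentration tested), compound 1 (`CC(=O)SCCC(CCCCC(=O)O)SC(C)=O`) gives 12.8%. Compound 2 (`O=C(CCCCC(S)CCS)Nc1ccc(F)cc1`) is recorded in the same test as "not active" (no number reported). It therefore has no single number, and its place is known only in words, which leaves no measured starting point for a step. Compound 3 (`O=C(CCCCC(S)CCS)Nc1ccc([N+](=O)[O-])cc1`) differs from compound 2 at one place on the aromatic ring: nitro in place of fluoro on an aromatic carbon. In words, this is nitro in place of fluoro on an aromatic carbon, para to a large group. Within the data shown here, no measured pair in this assay shows what such an exchange does. With compound 2 recorded as "not active" (no number reported), the expectation is a small upward step in growth inhibition, or none beyond the scatter. For compound 3 the estimated inhibition is 8%, with an expected range from 0% to 25%.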

Compound 3, percent growth inhibition at one concentration: 1.73%
Compound 3: middle estimate off by 6.3 percentage points, on the high side, and the stated range covers the measured number.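

Among these compounds, compound 2 is recorded only in words, without a number, so no step from it to compound 3 can be read. What nitro in place of fluoro does to growth inhibition stays open, and no evidence shown bears on the result of compound 3.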